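This account rests on a few compounds, and the source may have more. Where it says the series, first, only, none or still open, it means among the compounds named here.

Within the data shown here, in a functional assay on HT-29 cells (Homo sapiens) for inhibition, with a stated time of 72 h (a lower number here means a stronger inhibitor, a higher number a weaker inhibitor), compound 1 `COc1ccc(S(=O)(=O)N2CCc3cccc(-c4ccc(F)nc4)c32)cc1` gives 109 nM, the highest of the two numbers measured so far. Among the measured compounds shown here, its only neighbour is compound 2 `COc1ccc(S(=O)(=O)N2CCc3cccc(-c4ccc([N+](=O)[O-])cc4)c32)cc1`, which in this assay gives 51.8 nM. For the measured compounds named here, the single step joining them, a 2.1-fold lower number from compound 1 to compound 2 (0.32 log units; beyond the scatter), changes nothing but the group on the aromatic carbon of the shared core, and it was modest yet beyond the scatter.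

Compound 3 `COc1ccc(S(=O)(=O)N2CCc3cccc(-c4ccc(C#N)cc4)c32)cc1` has not yet been measured. It differs from compound 1 by 4-cyanophenyl in place of 6-fluoropyridin-3-yl on an aromatic carbon. The step from compound 1 to compound 2 bears directly on this change, since it also replaces the 6-fluoropyridin-3-yl with a six-membered aromatic ring of carbon only, and that step gave a lower number. A step of similar size and the same direction in this assay is therefore expected for compound 3, with the caution that a nitrile has not been tested on this core, so the expectation rests on one step alone. The expected step is a 1.8-fold lower number from compound 1 to compound 3 (0.26 log units; within the scatter). For compound 3 the estimate in this assay is 60 nM, with a range from 25 nM to 150 nM.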

Compound 3, half-maximal inhibitory concentration: 24.2 nM
Compound 3: middle estimate off by 2.5-fold (0.39 log units), on the high side; the whole stated range lies above it.
By their numbers in this assay, from the lowest: compound 3; then compound 2; then compound 1.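

In this assay, this aromatic carbon of the shared core distinguishes even between two groups on the same carbon-only ring, with a 2.1-fold lower number from compound 2 to compound 3 (0.33 log units; beyond the scatter) when cyano stands in place of nitro, so the earlier gain was not simply a matter of leaving the 6-fluoropyridin-3-yl behind. The full change from 6-fluoropyridin-3-yl to 4-cyanophenyl gives a 4.5-fold lower number from compound 1 to compound 3 (0.65 log units; beyond the scatter), a larger step than the one to 4-nitrophenyl, and it places compound 3 as the strongest inhibitor of the three, with its steps to both other compounds beyond the scatter. No measurement shown here accounts for the order of these three groups, so the result stands as an observation only.

From the compounds shown here alone, the change from compound 1 to compound 3 alters the ring and its substituent together, so how much of the step belongs to each remains open. Going by these compounds, it is also open whether the order would hold for an unsubstituted phenyl, or for a phenyl carrying an amine or a carboxylic acid in place of the nitrile.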